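Methyl on the fused ring of compound 3

The source may report more compounds than this note shows. Statements on the series, on what has been measured and on what is new or still open speak of the compounds shown alone.

Compound 1 `COc1ccc(-c2c(C(=O)c3cc(OC)c(OC)c(OC)c3)sc3ccccc23)cc1`: in a functional assay on A549 cells (Homo sapiens) for antiproliferative activity, read by MTT assay, with a stated time of 72 h (on this read-out lower numbers stand for stronger inhibition and higher numbers for weaker inhibition), compound 1 gives 4400 nM.
Compound 2 `COc1ccc(-c2c(C(=O)c3cc(OC)c(OC)c(OC)c3)sc3ccccc23)cc1C`: in this assay compound 2 gives > 10000 nM, which is a limit of the assay and not a number (the limit of > 10000 nM in this assay, at which 1 of the 3 values shown sits).
Compound 3 `COc1cc(C(=O)c2sc3ccccc3c2Nc2ccc(C)cc2)cc(OC)c1OC`: in this assay compound 3 gives 2600 nM.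

Compound 3 and compound 1 differ in their cores by (4-methylphenyl)amino in place of 4-methoxyphenyl on an aromatic carbon; this gave a 1.7-fold lower number from compound 1 to compound 3 (0.23 log units; within the scatter). Measured against compound 2 the same core change gave an at least 3.8-fold lower number from compound 2 to compound 3 (0.58 log units; beyond the scatter).

Among the measured compounds shown here, the one earlier methyl step, (methyl in place of hydrogen on an aromatic carbon), gave an at least 2.2-fold higher number from compound 1 to compound 2 (0.35 log units; beyond the scatter). Compound 4 `COc1cc(C(=O)c2sc3cc(C)ccc3c2Nc2ccc(C)cc2)cc(OC)c1OC` carries methyl in place of hydrogen on an aromatic carbon. This is the same kind of change, not the same: in compound 2 the methyl sits ortho to a methoxy group and meta to a large group, whereas in compound 4 the ring is part of a fused or bridged system of two rings and the methyl sits meta to a fused ring and para to a fused ring. For the measured compounds named here, only one such step has been measured, and it reads as a loss. Resting on an at least 2.2-fold higher number from compound 1 to compound 2 (0.35 log units; beyond the scatter), a step of similar size is expected for compound 4 a 1.9-fold higher number from compound 3 to compound 4 (0.28 log units; within the scatter), with wide bounds given the different place. Compound 4 is estimated at 5000 nM, between 1500 nM and 15000 nM.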

Compound 4, half-maximal inhibitory concentration: 1900 nM
Beside the measured number, compound 4's estimate is 2.6-fold (0.42 log units) above it; low and high end bracket the measured number.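

In this assay the methyl on the fused ring gave a 1.4-fold lower number from compound 3 to compound 4 (0.14 log units; within the scatter), so on the core of compound 3 this change moves the number by no more than the scatter. The same change did not read the same way on the two cores: the same change on two cores in this assay, an at least 2.2-fold higher number (0.35 log units; beyond the scatter) from compound 1 to compound 2 and a 1.4-fold lower number (0.14 log units; within the scatter) from compound 3 to compound 4, at least 3.1-fold (0.49 log units) apart, beyond the scatter of two such steps. Compound 2 gives > 10000 nM, which is a limit of the assay and not a number, and the two methyl groups sit in different places, so the gap shows that this change cannot simply be carried from one core to the other, but it does not separate the effect of the core from that of the place.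

From the compounds shown here alone, it remains open whether a methyl in this same place on the core of compound 1 would read as it does on compound 4. Also open, going by these compounds, is how an ethyl group, a methoxy group or an amine would read in that place on the core of compound 3.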